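A few compounds are considered here, and "the series" means these few. Any claim that something is new, unique, unknown or untested is made for them only; others in the source may bear on it.

Measured in a functional assay on MCF7 cells (Homo sapiens) for antiproliferative activity, read by MTT assay, with a stated time of 48 h; on this read-out lower numbers stand for stronger inhibition and higher numbers for weaker inhibition:
- Compound 1 `COC/C1=C/C[C@](C)(CCC=C(C)C)/C=C/[C@@H](OC(=O)C=C(C)C)[C@](C)(O)/C=C/C1=O`: 4130 nM
- Compound 2 `CC(C)=CCC[C@]1(C)/C=C/[C@@H](OC(=O)C=C(C)C)[C@](C)(O)/C=C/C(=O)/C(CN2CCN(C)CC2)=C\C1`: 550 nM
- Compound 3 `CC[Si](CC)(CC)C/C1=C/C[C@](C)(CCC=C(C)C)/C=C/[C@@H](OC(=O)C=C(C)C)[C@](C)(O)/C=C/C1=O`: 3150 nM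

Compound 3 sits among the higher numbers here. Its group shows a 1.3-fold lower number from compound 1 to compound 3 (0.12 log units; within the scatter), while losing the 4-methylpiperazin-1-yl group shows a 5.7-fold higher number from compound 2 to compound 3 (0.76 log units; beyond the scatter).

Compound 4 `CC(C)=CCC[C@]1(C)/C=C/[C@@H](OC(=O)C=C(C)C)[C@](C)(O)/C=C/C(=O)/C(CN=[N+]=[N-])=C\C1` carries azido instead, on a saturated chain carbon bound to a double-bonded ring carbon: a group of 3 heavy atoms (3 nitrogen; no ring) in place of a group of 7 heavy atoms (6 carbon, 1 silicon; no ring), on a saturated chain carbon bound to a double-bonded ring carbon.

For the measured compounds named here, only the 4-methylpiperazin-1-yl group has moved the number so far, with a 7.5-fold lower number from compound 1 to compound 2 (0.88 log units; beyond the scatter). Azido has not been tested, so this is a loose guide, and no step beyond the scatter is expected. In this assay the expected change is a 1.1-fold lower number from compound 3 to compound 4 (0.02 log units; within the scatter). The estimate for compound 4 is 3000 nM, with an expected range from 1000 nM to 8000 nM.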

Compound 4, half-maximal inhibitory concentration: 4890 nM
Compound 4: middle estimate off by 1.6-fold (0.21 log units), on the low side, and the stated range covers the measured number.
By their numbers in this assay, from the lowest: compound 2; then compounds 3, 1 and 4 (each within the scatter of the next).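

In this assay, azido at this place, on a saturated chain carbon bound to a double-bonded ring carbon, gives a result close to those of the two earlier groups: a 1.6-fold higher number from compound 3 to compound 4 (0.19 log units; within the scatter) and a 1.2-fold higher number from compound 1 to compound 4 (0.07 log units; within the scatter). Only 4-methylpiperazin-1-yl stands apart, with an 8.9-fold higher number from compound 2 to compound 4 (0.95 log units; beyond the scatter), so three quite different groups now sit level while this one does not. Nothing available here explains that gap. The compounds shown leave open whether an open-chain amine such as dimethylamino, or a morpholine ring, would match compound 2 at this place.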